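Trifluoromethyl in place of chloro on the phenyl arm

The source may hold more compounds than are shown below. What is called first, only, known or untested is meant among the compounds shown, and "the series" means these compounds.

Of the compounds shown here, three built on one shared core have been measured in a functional assay on PC-12 cells (Rattus norvegicus) for cytotoxicity, read by MTT assay, with stated times of 2 h and 24 h, tested at 10 uM; a higher number here means a stronger effect of the compound at the concentration tested, a lower number a weaker effect. Compound 1 `Oc1cc(C(F)(F)F)ccc1-c1nc(-c2ccccc2O)n(-c2ccc(F)cc2)n1` gives 99.8%. Compound 2 `Oc1cc(C(F)(F)F)ccc1-c1nc(-c2ccccc2O)n(-c2ccc(Cl)cc2)n1` gives 96.1% in this assay, and compound 3 `Oc1cc(C(F)(F)F)ccc1-c1nc(-c2ccccc2O)n(-c2cccc(Cl)c2)n1` gives 100%. The step of a number 3.7 percentage points lower from compound 1 to compound 2 (within the scatter) and the step of a number 3.9 percentage points higher from compound 2 to compound 3 (within the scatter) show that exchanging one substituted phenyl on the aromatic nitrogen for another left the read-out essentially unchanged, and the same holds for a number 0.2 percentage points higher from compound 1 to compound 3 (within the scatter). Compound 3 thus carries the highest of the three numbers, but its gaps to compound 1 and compound 2 are both within the scatter, so it cannot be called the strongest.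

Compound 4 `Oc1cc(C(F)(F)F)ccc1-c1nc(-c2ccccc2O)n(-c2cccc(C(F)(F)F)c2)n1` has not yet been measured. It differs from compound 3 in one place: trifluoromethyl in place of chloro on an aromatic carbon. For the measured compounds named here, no measured step involves a trifluoromethyl on this ring, so the three steps available, each within the scatter, bear on it only by showing that changing the group on this phenyl did not move the number, and all three values already sit near the top of the scale. A step of a number 2 percentage points lower from compound 3 to compound 4 (within the scatter) is therefore expected, meaning no change beyond the scatter. Compound 4 is estimated at 98%, with a range from 90% to 100%.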

Compound 4, a percentage reported as activity, at one concentration (the size of the read-out at that concentration, not a potency): 99.9%
Estimate against measurement, compound 4: 1.9 percentage points below; the range from low to high includes it.
By their numbers in this assay, from the lowest: compounds 2, 1, 4 and 3 (each within the scatter of the next).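

In this assay, trifluoromethyl, with 4 heavy atoms, takes the place of chloro, with 1, on an aromatic carbon of this phenyl arm, and the result is a number 0.1 percentage points lower from compound 3 to compound 4 (within the scatter): a much larger group at this spot leaves the read-out where it was. The comparisons across the whole arm agree, with a number 3.8 percentage points higher from compound 2 to compound 4 (within the scatter) and a number 0.1 percentage points higher from compound 1 to compound 4 (within the scatter), so 3-(trifluoromethyl)phenyl cannot be told apart from 4-chlorophenyl, 4-fluorophenyl or 3-chlorophenyl on the aromatic nitrogen, and all four compounds now sit together at the top of the scale. Nothing available here offers a reason for this flat result.

From the compounds shown here alone, all the groups on this arm so far are halogens or trifluoromethyl, so it remains open whether an amine, a carboxylic acid or a longer chain at the same place would shift the number. Going by these compounds, it is also open whether these four compounds would still read alike at a lower concentration, where the top of the scale would no longer hide differences between them.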